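Lengthening the linker once more in compound 3

The source may hold more compounds than are shown below. What is called first, only, known or untested is meant among the compounds shown, and "the series" means these compounds.

In an assay on BTI cells for inhibition of Amine oxidase [flavin-containing] B (Homo sapiens), read by fluorescence and Amplex Red, with a stated time of 15 min (a higher number here means a weaker inhibitor, a lower number a stronger inhibitor), compound 2 `C#CCN(C)CCCCCOc1ccc2c(c1)CCC2=O` gives 94.8 nM, the lowest of the two numbers recorded so far. Its nearest neighbour, compound 1 `C#CCN(C)CCCCOc1ccc2c(c1)CCC2=O`, gives 366 nM in this assay, and the step of a 3.9-fold lower number from compound 1 to compound 2 (0.59 log units; beyond the scatter) is modest but beyond the scatter. Compound 3 `C#CCN(C)CCCCCCOc1ccc2c(c1)CCC2=O` is not yet measured. It differs from compound 2 by (methyl(propargyl)amino)methyl in place of methyl(propargyl)amino on a saturated chain carbon, five bonds along the chain from an oxygen on an aromatic ring. Within the data shown here, only one measured step bears on this change, namely a 3.9-fold lower number from compound 1 to compound 2 (0.59 log units; beyond the scatter), which is the same kind of change four bonds along the chain from the oxygen on the aromatic ring and which lowered the number beyond the scatter. Compound 3 is therefore expected to give a somewhat lower number than compound 2 in this assay, though a second lengthening need not repeat the first and an outcome within the scatter of compound 2 remains quite possible. The estimate for compound 3 is 65 nM, with a range from 25 nM to 220 nM, which corresponds to an expected step of a 1.5-fold lower number from compound 2 to compound 3 (0.16 log units; within the scatter).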

Compound 3, half-maximal inhibitory concentration: 129 nM
Estimate against measurement, compound 3: 2.0-fold (0.30 log units) below; measured number inside the range.
By their numbers in this assay, from the lowest: compounds 2 and 3 (each within the scatter of the next); then compound 1.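

In this assay, the change that helped at the earlier step, made one place further out, five bonds along the chain from an oxygen on an aromatic ring, gives a 1.4-fold higher number from compound 2 to compound 3 (0.13 log units; within the scatter), so compound 2 and compound 3 cannot be told apart and the second lengthening does not repeat the effect of the first. Compound 3 still stands clear of compound 1, since 2-(methyl(propargyl)amino)ethyl in place of methyl(propargyl)amino, four bonds along the chain from the oxygen, gives a 2.8-fold lower number from compound 1 to compound 3 (0.45 log units; beyond the scatter); the difference between the shortest chain and the two longer ones therefore holds, while the two longer chains form a level stretch rather than a continuing trend. Nothing available here speaks to why the second lengthening behaved differently from the first.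

The compounds shown leave open whether a longer chain than that of compound 3 would stay level with compound 2 and compound 3 or climb back towards compound 1. They also leave open whether this level stretch would survive an ethyl group in place of the methyl on the nitrogen, with the shared core unchanged.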